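A few compounds are considered here, and "the series" means these few. Any claim that something is new, unique, unknown or untested is made for them only; others in the source may bear on it.

Of the compounds shown here, three from one series have been measured in a physicochemical assay for lipophilicity, using the shake flask method, at pH 7.4; a higher number here means a more lipophilic compound, a lower number a more polar compound. Compound 1 `COc1ccc(CNC(=O)c2nc(-c3ccc(F)cc3)n(CC[C@@H](O)C[C@@H](O)CC(=O)O)c2C2CC2)cc1` gives 0.02 in this assay. Compound 2 `CC(C)c1c(C(=O)NCc2ccccc2)nc(-c2ccc(F)cc2)n1CC[C@@H](O)C[C@@H](O)CC(=O)O` gives 0.64 in this assay, and compound 3 `Cc1ccc(CNC(=O)c2nn(-c3ccc(F)cc3)c(CC[C@@H](O)C[C@@H](O)CC(=O)O)c2C(C)C)cc1` gives 0.24. Compound 1 holds the lowest of the three numbers, but the gap to compound 3 lies within the usual scatter of the method, so those two cannot be told apart, while the gap to compound 2 lies beyond the scatter.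

Compound 4 `CN(C)S(=O)(=O)c1ccc(CNC(=O)c2nc(-c3ccc(F)cc3)n(CC[C@@H](O)C[C@@H](O)CC(=O)O)c2C2CC2)cc1` has not yet been measured in this assay. It differs from compound 1 in one place:

dimethylsulfamoyl in place of methoxy on an aromatic carbon

Within the data shown here, no pair among the measured compounds carries this same change, so nothing measured here shows its size directly. A downward step is nevertheless expected, one larger than the scatter: in this assay the expected step is a number 0.62 log units lower from compound 1 to compound 4 (beyond the scatter). This expectation rests on the change itself and on the value of compound 1 0.02 as the starting point, not on any measured pair. For compound 4 the estimate in this assay is -0.6, with a range from -1.2 to 0, the width reflecting that the step has not been seen in this series.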

Compound 4, distribution coefficient: -0.46
Compound 4: middle estimate off by 0.14 log units, on the low side; the range from low to high includes it.
By their numbers in this assay, from the lowest: compound 4; then compounds 1 and 3 (each within the scatter of the next); then compound 2.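

Among these compounds, the first single-place comparison comes from this assay, where replacing 4-methoxyphenyl with 4-(dimethylsulfamoyl)phenyl gives a number 0.48 log units lower from compound 1 to compound 4 (beyond the scatter) and so shows that the read-out responds to a change at this position. The site is an aromatic carbon of a six-membered aromatic ring of carbon only, para to a large group, and the rest of the molecule stays the same in this pair, so the step belongs to this one exchange of groups. Dimethylsulfamoyl brings 6 heavy atoms and 2 hydrogen-bond acceptors where methoxy has 2 heavy atoms and 1 hydrogen-bond acceptor, but one pair cannot separate these differences, and nothing available here explains the size of the step.

As far as these compounds go, it remains open whether a smaller sulfonamide, an amine or a carboxylic acid at the same position would shift the number in the same direction and by a similar amount. The compounds shown also leave open whether dimethylsulfamoyl would give a comparable step on the cores of compound 2 and compound 3, which carry other groups elsewhere.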